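From Compound 2 to Compound 4: One Group Exchanged

This account rests on a few compounds, and the source may have more. Where it says the series, first, only, none or still open, it means among the compounds named here.

In a physicochemical assay for lipophilicity, measured as octanol-water partition, at pH 7.4 (on this read-out higher numbers stand for higher lipophilicity and lower numbers for lower lipophilicity), compound 1 (`O=C(N[C@H]1CN(S(=O)(=O)c2ccccc2)C[C@@H]1C(=O)NC[C@@H]1CCCN1)c1cc(-c2ccccc2Cl)on1`) gives 1.5. Compound 2 (`CN(C(=O)[C@H]1CN(S(=O)(=O)c2ccccc2)C[C@@H]1NC(=O)c1cc(-c2ccccc2Cl)on1)[C@H]1CCCNC1`) gives 1.7, and compound 3 (`CN(C(=O)[C@H]1CN(S(=O)(=O)c2ccccc2)C[C@@H]1N(C)C(=O)c1cc(-c2ccccc2Cl)on1)[C@H]1CCCNC1`) gives 1.6. Compound 2 therefore stands within the scatter of both of the others. For the measured compounds named here, two measured steps bear on it. One is a number 0.20 log units higher from compound 1 to compound 2 (within the scatter), where one group on a carbonyl carbon was exchanged for another. The other is a number 0.10 log units lower from compound 2 to compound 3 (within the scatter), where methyl took the place of hydrogen on an amide-type nitrogen.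

Compound 4 (`CC(=O)N1CCC[C@H](NC(=O)[C@H]2CN(S(=O)(=O)c3ccccc3)C[C@@H]2NC(=O)c2cc(-c3ccccc3Cl)on2)C1`) has not yet been measured. The change that leads to it is a group of 10 heavy atoms (7 carbon, 2 nitrogen, 1 oxygen; one six-membered non-aromatic ring with 1 hetero atom) in place of a group of 8 heavy atoms (6 carbon, 2 nitrogen; one six-membered non-aromatic ring with 1 hetero atom), on a carbonyl carbon. It falls on a carbonyl carbon whose other neighbours are: saturated ring carbon. Both groups hold one six-membered non-aromatic ring with 1 hetero atom, and only the entering group has 1 double bond outside aromatic rings.

The step of a number 0.20 log units higher from compound 1 to compound 2 (within the scatter) concerns the same place, but it exchanges a different pair of groups. Neither measured step therefore gives a direct size for this change, and a rise beyond those small steps is expected only tentatively. The estimated step is a number 0.50 log units higher from compound 2 to compound 4 (beyond the scatter). For compound 4 the expected value in this assay is 2.2, with an estimated range from 1.7 to 2.8.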

Compound 4, distribution coefficient: 3.5
Beside the measured number, compound 4's estimate is 1.30 log units below it; the measured number lies above the stated range.
By their numbers in this assay, from the lowest: compounds 1, 3 and 2 (each within the scatter of the next); then compound 4.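

This exchange on a carbonyl carbon is the first step shown in this assay to lie beyond the scatter: a number 1.80 log units higher from compound 2 to compound 4 (beyond the scatter). For the compounds shown here, the step of a number 2.00 log units higher from compound 1 to compound 4 (beyond the scatter), with 1-acetylpiperidin-3-yl in place of (pyrrolidin-2-yl)methyl on an amide-type nitrogen, is also large, whereas the exchange between the groups of the earlier compounds stayed small at a number 0.20 log units higher from compound 1 to compound 2 (within the scatter), so this place can carry a large change in the read-out, depending on the pair of groups exchanged. Both groups in the step to compound 4 hold one six-membered non-aromatic ring with 1 hetero atom and have equal computed donor and acceptor counts, so the large step comes without a difference in those features, and nothing shown here accounts for its size.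

From the compounds shown here alone, what remains open is whether the rise goes with the acetyl itself or with the entering group as a whole. A propanoyl or a methanesulfonyl group in place of the acetyl, or a simple methyl there, would bear on that question, as would a free carboxylic acid carried on the same ring.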